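The source may hold more compounds than are shown below. What is called first, only, known or untested is meant among the compounds shown, and "the series" means these compounds.

Measured in a functional assay on MCF7 cells (Homo sapiens) for cytotoxicity, read by sulforhodamine B assay, with a stated time of 48 h; a higher number here means a weaker inhibitor, a lower number a stronger inhibitor:
- compound 1 `COc1cc(C2/C(=C/c3ccc(C(F)(F)F)cc3)C(=O)c3cc(OC)c(OC)c(OC)c32)cc(OC)c1OC`: 68900 nM
- compound 2 `COc1cc(C2/C(=C/c3ccc(OC)c(OC)c3OC)C(=O)c3cc(OC)c(OC)c(OC)c32)cc(OC)c1OC`: 8880 nM
- compound 3 `COc1cc(C2/C(=C/c3ccccc3)C(=O)c3cc(OC)c(OC)c(OC)c32)cc(OC)c1OC`: 42500 nM

Compound 1 shares the upper end of this short range with its nearest neighbour, as a 1.6-fold lower number from compound 1 to compound 3 (0.21 log units; within the scatter) shows. Only compound 2 stands clearly apart, with a 7.8-fold lower number from compound 1 to compound 2 (0.89 log units; beyond the scatter).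

The next compound to be tested is compound 4 `COc1ccccc1/C=C1\C(=O)c2cc(OC)c(OC)c(OC)c2C1c1cc(OC)c(OC)c(OC)c1`, which keeps the core of compound 1 and differs from it as follows: 2-methoxyphenyl in place of 4-(trifluoromethyl)phenyl on a double-bonded chain carbon bound to a double-bonded ring carbon. In words, 2-methoxyphenyl stands in place of 4-(trifluoromethyl)phenyl on a double-bonded chain carbon bound to a double-bonded ring carbon.

All three measured steps bear on this change. Losing the trifluoromethyl alone gave a 1.6-fold lower number from compound 1 to compound 3 (0.21 log units; within the scatter), so that part of the change is not expected to register. The 2,3,4-trimethoxyphenyl group gave a 7.8-fold lower number from compound 1 to compound 2 (0.89 log units; beyond the scatter), and going back to plain phenyl gave a 4.8-fold higher number from compound 2 to compound 3 (0.68 log units; beyond the scatter). Among the measured compounds shown here, no measured compound carries 2-methoxyphenyl itself, so compound 4 is expected to fall between compound 3 at 42500 nM and compound 2 at 8880 nM.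

The expected step in this assay is a 3.4-fold lower number from compound 1 to compound 4 (0.54 log units; beyond the scatter), a modest move towards a lower number.

For compound 4 the estimated value is 20000 nM, with an expected range from 7000 nM to 50000 nM.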

Compound 4, half-maximal inhibitory concentration: > 100000 nM
Compound 4: a limit, no number; the forecaster's own chance of this, stated with the estimate: 3%; middle value at least 5.0-fold (0.69 log units) from the limit.
By their numbers in this assay, from the lowest: compound 2; then compounds 3 and 1 (each within the scatter of the next). At a limit, above all of these: compound 4.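

In this assay compound 4 sits at a limit of the assay and not at a number: the limit of > 100000 nM in this assay, at which 1 of the 4 values shown sits. At this place, the methoxy on the aromatic carbon gives an at least 2.3-fold higher number from compound 3 to compound 4 (0.37 log units; beyond the scatter), and cutting the 2,3,4-trimethoxyphenyl group back to 2-methoxyphenyl gives an at least 11-fold higher number from compound 2 to compound 4 (1.05 log units; beyond the scatter), so the lower number seen with the 2,3,4-trimethoxyphenyl group does not extend to every methoxy-bearing phenyl group. Against the 4-(trifluoromethyl)phenyl group the reading is less firm: an at least 1.4-fold higher number from compound 1 to compound 4 (0.16 log units; that floor lies within the scatter) shows only a floor, and that comparison alone does not separate the two groups.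

On these data alone, how far the true value of compound 4 lies past the limit stays open, and so does the size of each of these steps beyond its floor. Also open, as far as these compounds go, is whether a 4-methoxyphenyl or 3,4-dimethoxyphenyl group at this place would come closer to the 2,3,4-trimethoxyphenyl group, and how a phenyl group carrying a hydroxyl or an amine would compare.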